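Swapping a chlorophenyl for a cyclohexyl at the chain end

The source may hold more compounds than are shown below. What is called first, only, known or untested is meant among the compounds shown, and "the series" means these compounds.

Compound 2 `O=C(CCCCCCn1cc(Nc2ncc3ccn(Cc4ccccc4Cl)c3n2)cn1)NO` gives 41.5 nM in an assay on isolated protein for inhibition of protein deacetylase HDAC6 (Homo sapiens), with a stated time of 60 min; on this read-out lower numbers stand for stronger inhibition and higher numbers for weaker inhibition. Compound 1 `O=C(CCCCCn1cc(Nc2ncc3ccn(Cc4ccccc4Cl)c3n2)cn1)NO` gives 45 nM, and a 1.1-fold lower number from compound 1 to compound 2 (0.04 log units; within the scatter). Compound 3 `O=C(CCCCCn1cc(Nc2ncc3ccn(Cc4cccc(F)c4)c3n2)cn1)NO` gives 13.7 nM, a lower number than compound 2; among the three, compound 2 holds the second highest number. Compound 4 `O=C(CCCCCCn1cc(Nc2ncc3ccn(CC4CCCCC4)c3n2)cn1)NO` carries cyclohexyl in place of 2-chlorophenyl on a saturated chain carbon bound to an aromatic nitrogen. For the measured compounds named here, only one measured step touches this place: a 3.3-fold lower number from compound 1 to compound 3 (0.52 log units; beyond the scatter), which exchanged one aromatic ring for another and gave a modest change. Going by the values given here, no measured step exchanges an aromatic ring for a non-aromatic ring at this place; the direction is open. The expected step is a 1.1-fold higher number from compound 2 to compound 4 (0.04 log units; within the scatter), of uncertain sign and with a wide range. Compound 4 is therefore estimated at 45 nM, between 15 nM and 150 nM.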

Compound 4, half-maximal inhibitory concentration: 88 nM
The estimate for compound 4 lay 2.0-fold (0.29 log units) below the measured number; the measured number falls inside the stated range.
By their numbers in this assay, from the lowest: compound 3; then compounds 2, 1 and 4 (each within the scatter of the next, the first and the last beyond it).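

The earlier step at this place only exchanged one aromatic ring for another. This result shows that a non-aromatic ring is also tolerated in this assay, with a 2.1-fold higher number from compound 2 to compound 4 (0.33 log units; beyond the scatter), a modest weakening that leaves inhibition measurable. No supporting measurement shown here accounts for this step.

The change removes the chlorine and the aromatic ring together, so the compounds shown do not separate the two. On these data alone, what an unsubstituted phenyl, or a piperidinyl ring carrying an amine, would give at this place remains open.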